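A few compounds are considered here, and "the series" means these few. Any claim that something is new, unique, unknown or untested is made for them only; others in the source may bear on it.

Measured in an assay for inhibition of protein kinase C iota type (Homo sapiens), read by mobility shift assay, with a stated time of 60 min; a higher number here means a weaker inhibitor, a lower number a stronger inhibitor:
- compound 1 `Nc1ncccc1C(=O)Nc1ccncc1` gives 22000 nM
- compound 2 `CC(C)(C)c1cc(NC(=O)c2nccnc2N)ccn1` gives 24000 nM

Compound 1 stands at the lower of the two numbers in this assay, but its gap to compound 2 is within the scatter, so the two count as equal. Within the data shown here, no step between measured compounds is available to guide the next change.

Compound 3 `Nc1ncc(-c2ccccc2)cc1C(=O)Nc1ccncc1` differs from compound 1 by phenyl in place of hydrogen on an aromatic carbon. With nothing measured for such a change in this assay, a modest move toward a lower number is expected, though a null result within the scatter stays plausible; the expected step is a 2.4-fold lower number from compound 1 to compound 3 (0.39 log units; beyond the scatter). For compound 3 the estimate is 9000 nM, with a range from 1500 nM to 40000 nM.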

Compound 3, half-maximal inhibitory concentration: 32000 nM
Beside the measured number, compound 3's estimate is 3.6-fold (0.55 log units) below it, within the range that was stated.
By their numbers in this assay, from the lowest: compounds 1, 2 and 3 (each within the scatter of the next).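

In this assay the step is a 1.5-fold higher number from compound 1 to compound 3 (0.16 log units; within the scatter) for phenyl in place of hydrogen on an aromatic carbon, para to an amino group. This position therefore accommodates a whole phenyl ring with no change that can be told from the scatter, and the added ring brings no gain. No available measurement bears on why this is so.

Going by these compounds, whether a methyl group, a chlorine atom, or a phenyl carrying an amine or a carboxylic acid at this position would separate from compound 1 stays open. Also open, on these data alone, is whether phenyl would behave alike on the core of compound 2.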